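Series notes: estimating compound 4 from compound 1

A few compounds are considered here, and "the series" means these few. Any claim that something is new, unique, unknown or untested is made for them only; others in the source may bear on it.

compound 1 `COc1cc(O)c(C(=O)OCC2CCCCC2)c(/C=C/CN2C(=O)C=CC2=O)c1` — 71%
compound 2 `C=CS(=O)(=O)NC/C=C/c1cc(OC)cc(O)c1C(=O)OCc1ccc(Br)cc1` — 8.1%
compound 3 `C=CS(=O)(=O)NC/C=C/c1cc(OC)cc(O)c1C(=O)OCC1CCCCC1` — 7.5%

In a functional assay on HL-60 cells (Homo sapiens) for inhibition, read by luminescence, with a stated time of 72 h, tested at 5 uM (on this read-out lower numbers stand for less inhibition of growth and higher numbers for more inhibition of growth at the one concentration tested), compound 1 gives the highest number of the three, with compound 2 and compound 3 each far below it; the step of a number 63.5 percentage points lower from compound 1 to compound 3 (beyond the scatter) is large and lies on the saturated chain carbon bound to a double-bonded chain carbon. Compound 4 `COc1cc(O)c(C(=O)OCC(C)c2ccccc2)c(/C=C/CN2C(=O)C=CC2=O)c1` is not yet measured and differs from compound 1 at one place only: 1-phenylethyl in place of cyclohexyl on a saturated chain carbon bound to an oxygen next to a carbonyl group. Among the compounds with values here, the single measured step at this place, a number 0.6 percentage points lower from compound 2 to compound 3 (within the scatter), lies within the scatter, so in this assay no step beyond the scatter is expected in either direction. Compound 4 is therefore expected close to compound 1, at 68% (range 50% to 85%), which means an expected step of a number 3 percentage points lower from compound 1 to compound 4 (within the scatter).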

Compound 4, percent growth inhibition at one concentration: 56%
Beside the measured number, compound 4's estimate is 12 percentage points above it; measured number inside the range.
By their numbers in this assay, from the lowest: compounds 3 and 2 (each within the scatter of the next); then compound 4; then compound 1.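

In this assay, within the data shown here, the step of a number 15 percentage points lower from compound 1 to compound 4 (beyond the scatter) is the first beyond the scatter at the saturated chain carbon bound to an oxygen next to a carbonyl group, so this place is not silent on the core of compound 1. The earlier step of a number 0.6 percentage points lower from compound 2 to compound 3 (within the scatter) showed no such change, though it involved a different swap on a different background, and the new step remains smaller than a number 63.5 percentage points lower from compound 1 to compound 3 (beyond the scatter) at the other place. No measurement shown here accounts for the new step.

Still open, on these data alone, is whether the aromatic ring or the larger carbon count of 1-phenylethyl goes with the lower number. A plain benzyl group or a longer saturated chain at this place on the same core could separate the two.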